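Ethyl to Cyclopropyl Next to the Ring Nitrogen

A few compounds are considered here, and "the series" means these few. Any claim that something is new, unique, unknown or untested is made for them only; others in the source may bear on it.

Of the compounds shown here, three have been measured in an assay on cells for inhibition of cytochrome P450 11B2, mitochondrial (Homo sapiens), read by HPLC, with a stated time of 90 min; a higher number here means a weaker inhibitor, a lower number a stronger inhibitor. Compound 1 `Fc1ccc2nc(-c3cn[nH]c3)n(C3CC3)c2c1` gives 782 nM, compound 2 `Fc1cc2nc(-c3cncnc3)n(C3CC3)c2cc1F` gives 22 nM, and compound 3 `CCc1ncncc1-c1nc2cc(F)c(F)cc2n1C1CC1` gives 8 nM, the lowest number of the three, with compound 2 nearest and compound 1 furthest away. Among the measured compounds shown here, the only step between compounds differing in one place, a 2.8-fold lower number from compound 2 to compound 3 (0.44 log units; beyond the scatter), shows that adding ethyl at this aromatic carbon helped. Compound 4 `Fc1cc2nc(-c3cncnc3C3CC3)n(C3CC3)c2cc1F` carries the change (cyclopropyl in place of ethyl on an aromatic carbon). For the measured compounds named here, no measured pair swaps one carbon group for another at this place, so only the step from compound 2 to compound 3 bears on it, and it suggests a carbon group there is tolerated. A change no larger than the scatter is expected, so a 1.3-fold lower number from compound 3 to compound 4 (0.12 log units; within the scatter) is the estimate. Compound 4 is therefore expected to give 6 nM, within the range 2.5 nM to 15 nM.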

Compound 4, half-maximal inhibitory concentration: 172 nM
Compound 4: middle estimate off by 29-fold (1.46 log units), on the low side; measured number above the stated range.
By their numbers in this assay, from the lowest: compound 3; then compound 2; then compound 4; then compound 1.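

At this place on the ring, in this assay, ethyl and cyclopropyl are not interchangeable carbon groups (a 22-fold higher number from compound 3 to compound 4 (1.33 log units; beyond the scatter)). Cyclopropyl even falls behind plain hydrogen (a 7.8-fold higher number from compound 2 to compound 4 (0.89 log units; beyond the scatter)), so the gain seen with ethyl does not extend to every carbon group. Nothing available explains this difference between the two groups.

On these data alone, whether methyl, isopropyl or a longer chain such as propyl would behave like ethyl or like cyclopropyl stays open. So does the outcome for a methoxy group or an amine at this place.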